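Fluoro to chloro: what should compound 4 do?

This account rests on a few compounds, and the source may have more. Where it says the series, first, only, none or still open, it means among the compounds named here.

In a functional assay on HeLa cells (Homo sapiens) for cytotoxicity, read by MTT assay, with a stated time of 72 h (a lower number here means a stronger inhibitor, a higher number a weaker inhibitor), compound 1 (`Cn1ccc2c(Oc3ccc(NC(=O)c4cc5cccnc5n(-c5ccc(Cl)cc5)c4=O)cc3)ncnc21`) gives 49900 nM and compound 2 (`Cn1ccc2c(Oc3ccc(NC(=O)c4cc5cccnc5n(-c5ccccc5)c4=O)cc3F)ncnc21`) gives 51800 nM. Compound 3 (`Cn1ccc2c(Oc3ccc(NC(=O)c4cc5cccnc5n(-c5ccc(F)cc5)c4=O)cc3F)ncnc21`) gives 4250 nM, the lowest of the three numbers, with both others well above it. Compound 4 (`Cn1ccc2c(Oc3ccc(NC(=O)c4cc5cccnc5n(-c5ccc(Cl)cc5)c4=O)cc3F)ncnc21`) differs from compound 3 in one place: chloro in place of fluoro on an aromatic carbon. This puts chloro in place of fluoro on an aromatic carbon, para to a large group. Among the measured compounds shown here, one measured step bears on this carbon: a 12-fold lower number from compound 2 to compound 3 (1.09 log units; beyond the scatter), a large step beyond the scatter, with fluoro in place of hydrogen. That step shows that a change here can move the number, but it compares hydrogen with fluoro. For the measured compounds named here, no measured pair swaps fluoro for chloro directly, so the starting point remains compound 3 at 4250 nM. The expected step in this assay is small, a 1.4-fold higher number from compound 3 to compound 4 (0.15 log units; within the scatter), toward a higher number and within the scatter. For compound 4 the estimated value is 6000 nM, with an expected range from 1500 nM to 25000 nM.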

Compound 4, half-maximal inhibitory concentration: 43900 nM
Compound 4: the middle estimate sits 7.3-fold (0.86 log units) below what was measured; the whole stated range lies below it.
By their numbers in this assay, from the lowest: compound 3; then compounds 4, 1 and 2 (each within the scatter of the next).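

Chloro does not stand in for fluoro on this carbon: in this assay, the change gives a 10-fold higher number from compound 3 to compound 4 (1.01 log units; beyond the scatter). Chloro in place of hydrogen gives only a 1.2-fold lower number from compound 2 to compound 4 (0.07 log units; within the scatter), so among hydrogen, fluoro and chloro on this carbon, only fluoro brings the large drop. Fluoro in place of hydrogen also gives just a 1.1-fold lower number from compound 1 to compound 4 (0.06 log units; within the scatter), so the same change does not have one fixed effect across these compounds: the same change on two cores in this assay, a 12-fold lower number (1.09 log units; beyond the scatter) from compound 2 to compound 3 and a 1.1-fold lower number (0.06 log units; within the scatter) from compound 1 to compound 4, 11-fold (1.03 log units) apart, beyond the scatter of two such steps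

On these data alone, it remains open whether the low number of compound 3 is unique to fluoro or would also appear with another group on this carbon, such as methyl, methoxy or nitrile. The compounds shown also leave open how the 4-fluorophenyl group behaves when the other fluoro of compound 3 is replaced by hydrogen.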